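This account rests on a few compounds, and the source may have more. Where it says the series, first, only, none or still open, it means among the compounds named here.

Of the compounds shown here, three have been measured in a functional assay on LNCaP cells (Homo sapiens) for antiproliferative activity, read by propidium iodide staining, with a stated time of 96 h; on this read-out higher numbers stand for weaker inhibition and lower numbers for stronger inhibition. Compound 1 `CC(O)(CSc1cccc(S(F)(F)(F)(F)F)c1)C(=O)Nc1ccc(C#N)c(C(F)(F)F)c1` and compound 2 `CC(O)(CSc1cccc(S(F)(F)(F)(F)F)c1)C(=O)Nc1ccc([N+](=O)[O-])c(C(F)(F)F)c1` share an open-chain core and differ in one place: cyano in place of nitro on an aromatic carbon. In this assay compound 2 gives 8600 nM, and compound 1 gives 14500 nM. The step between them is a 1.7-fold higher number from compound 2 to compound 1 (0.23 log units; within the scatter), so these two numbers cannot be told apart. Compound 3 `CC1(C)C(=O)N(c2ccc([N+](=O)[O-])c(C(F)(F)F)c2)C(=S)N1c1cccc(S(F)(F)(F)(F)F)c1` is built on a ring-closed core; how that core differs from the core of compound 2 is not broken down here. In this assay compound 3 gives 100000 nM, the highest of the three numbers and beyond the scatter from both compound 1 and compound 2.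

Compound 4 `CC1(C)C(=O)N(c2ccc(C#N)c(C(F)(F)F)c2)C(=S)N1c1cccc(S(F)(F)(F)(F)F)c1` has not yet been measured. It stands to compound 3 as compound 1 stands to compound 2, with the same change at the same place: cyano in place of nitro on an aromatic carbon. Among the measured compounds shown here, the only measured instance of this change is a 1.7-fold higher number from compound 2 to compound 1 (0.23 log units; within the scatter), a step inside the scatter. For compound 4 the expected step is therefore no change at the digits printed from compound 3 to compound 4 (within the scatter), resting on that earlier step and on the fact that compound 3 already sits at 100000 nM. A number this high may also come back from the assay as a limit rather than a value. The estimate for compound 4 is 100000 nM, with a likely range from 40000 nM to 250000 nM.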

Compound 4, half-maximal inhibitory concentration: 6900 nM
The estimate for compound 4 lay 14-fold (1.16 log units) above the measured number; measured number outside the range, below it.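

In this assay, among the compounds shown here, putting cyano in place of nitro on the ring-closed core gives a 14-fold lower number from compound 3 to compound 4 (1.16 log units; beyond the scatter), a large step, whereas the same change on the open-chain core gave no step that could be told from the scatter. Set side by side, the two results show that the size of this change did not carry over from one core to the other: the same change on two cores in this assay, a 1.7-fold higher number (0.23 log units; within the scatter) from compound 2 to compound 1 and a 14-fold lower number (1.16 log units; beyond the scatter) from compound 3 to compound 4, 24-fold (1.39 log units) apart, beyond the scatter of two such steps. This shows that, among these four compounds, what the swap does depends on the core that carries it, but with only one pair on each core it gives no rule for any further core and does not explain why the two steps differ.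

From the compounds shown here alone, only nitro and cyano appear at this place on the aromatic ring, so it remains open whether a carboxylic acid, an amine or a simple chlorine atom there would follow the large step seen on the ring-closed core or the flat one seen on the open-chain core. Going by these compounds, all four compounds also keep the trifluoromethyl group on that ring, so it is equally open whether the gap between the two cores would survive with a methyl group in its place.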